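This account rests on a few compounds, and the source may have more. Where it says the series, first, only, none or still open, it means among the compounds named here.

Compound 1 `CN(C)C(=S)N/N=C/c1ccc2ccccc2n1`: 30 nM
Compound 2 `NC(=S)N/N=C/c1nc2ccccc2s1`: > 100000 nM

Among the compounds with values here, in a functional assay on SGC-7901 cells (Homo sapiens) for antiproliferative activity, read by sulforhodamine B assay, with a stated time of 72 h (on this read-out higher numbers stand for weaker inhibition and lower numbers for stronger inhibition), compound 1 gives 30 nM, the only true number among the values shown. Compound 2 reaches only (the limit of > 100000 nM in this assay, at which 1 of the 2 values shown sits), which is a limit of the assay and not a number. Compound 3 `NC(=S)N/N=C/c1ccc2ccccc2n1` keeps the core of compound 1 and carries amino in place of dimethylamino on a thiocarbonyl carbon. Within the data shown here, no such step between measured compounds exists here, so its size is a matter of expectation. Compound 2, which also carries an amino group on its thiocarbonyl carbon, returned only a limit. The step is therefore expected to weaken inhibition, estimated at a 100-fold higher number from compound 1 to compound 3 (2.00 log units; beyond the scatter). Compound 3 is thus expected near 3000 nM, within 300 nM to 30000 nM.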

Compound 3, half-maximal inhibitory concentration: 32700 nM
Estimate against measurement, compound 3: 11-fold (1.04 log units) below; measured number above the stated range.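

In this assay, within the data shown here, amino in place of dimethylamino on a thiocarbonyl carbon brings a 1100-fold higher number from compound 1 to compound 3 (3.04 log units; beyond the scatter), the only measured step at this place, so on the core of compound 1 inhibition depends heavily on the dimethylamino group. Compound 2, which also carries amino on its thiocarbonyl carbon, gives only a limit of the assay and not a number: the limit of > 100000 nM in this assay, at which 1 of the 3 values shown sits.

The compounds shown leave open where methylamino or diethylamino would fall at this place. They also leave open whether dimethylamino would bring a similar step on the core of compound 2.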